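Meta-substituent swap on the anilino ring of the series

The compounds below may be only part of what the source reports. "The series", "measured", "known", "first", "only" and "open" are said of these compounds alone.

Compound 2 `Nc1ccccc1NC(=O)c1ccc(Cn2cnc3c(Nc4cccc(OC(F)(F)F)c4)nc(Cl)nc32)cc1` is the weaker of the two measured compounds in a functional assay on HepG2 cells (Homo sapiens) for antiproliferative activity, read by CCK-8 assay, with a stated time of 72 h, tested at 2 uM; a higher number here means a stronger effect of the compound at the concentration tested, a lower number a weaker effect: compound 2 gives 1.88% there. Among the compounds with values here, the only other measured compound is compound 1 `Nc1ccccc1NC(=O)c1ccc(Cn2cnc3c(Nc4ccccc4)nc(Cl)nc32)cc1`, which in this assay gives 49.6%. Within the data shown here, the single step available, a number 47.7 percentage points lower from compound 1 to compound 2 (beyond the scatter), concerns the same ring position that changes next.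

Compound 3 `Nc1ccccc1NC(=O)c1ccc(Cn2cnc3c(Nc4cccc(Cl)c4)nc(Cl)nc32)cc1` is the unmeasured analogue. chloro in place of trifluoromethoxy on an aromatic carbon Put otherwise, trifluoromethoxy leaves and chloro enters on an aromatic carbon of a six-membered aromatic ring of carbon only, meta to a large group.

Among the measured compounds shown here, the only step that bears on this change is a number 47.7 percentage points lower from compound 1 to compound 2 (beyond the scatter): placing trifluoromethoxy at this position removed most of the inhibition. Chloro at the same position has no measured counterpart, so the size of the step from compound 2 is open; chloro is neither hydrogen nor trifluoromethoxy, and compound 3 is therefore expected to land between the two measured values rather than outside them. For compound 3 the expected step is a number 23.1 percentage points higher from compound 2 to compound 3 (beyond the scatter), upward but uncertain. The estimate for compound 3 is 25%, with a range from 2% to 55%.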

Compound 3, a percentage reported as inhibition, at one concentration (the size of the read-out at that concentration, not a potency): 29.9%
Compound 3: middle estimate off by 4.9 percentage points, on the low side; the range from low to high includes it.
By their numbers in this assay, from the lowest: compound 2; then compound 3; then compound 1.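

In this assay, the new result shows that the loss seen with trifluoromethoxy is not the fixed price of any substituent at this position: chloro in its place gives a number 28 percentage points higher from compound 2 to compound 3 (beyond the scatter), recovering a substantial part of the inhibition. Chloro is still not neutral here, since replacing hydrogen with it gives a number 19.7 percentage points lower from compound 1 to compound 3 (beyond the scatter), so both substituted compounds read lower than compound 1. Among these three compounds, the outcome therefore depends on which group occupies this position and not only on whether a substituent is present, with the numbers falling in the order hydrogen, chloro, trifluoromethoxy.

Nothing available explains this order. Open questions are whether a methyl, methoxy, amine or carboxylic acid group at this position would read closer to compound 1 or closer to compound 2, and whether the same order of hydrogen, chloro and trifluoromethoxy would hold elsewhere on the same ring.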